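A few compounds are considered here, and "the series" means these few. Any claim that something is new, unique, unknown or untested is made for them only; others in the source may bear on it.

Of the compounds shown here, three built on one shared core have been measured in a functional assay on MGC-803 cells (Homo sapiens) for antiproliferative activity, read by CCK-8 assay, with a stated time of 72 h, tested at 2 uM; on this read-out lower numbers stand for a weaker effect and higher numbers for a stronger effect at the one concentration tested. Compound 1 `Nc1ccccc1NC(=O)c1ccc(CSC(=S)N2CCN(c3ccc(Cl)cc3)CC2)cc1` gives 15% in this assay. Compound 2 `Nc1ccccc1NC(=O)c1ccc(CSC(=S)N2CCN(Cc3ccncc3)CC2)cc1` gives 18.4% in this assay. Compound 3 `COc1ccc(N2CCN(C(=S)SCc3ccc(C(=O)Nc4ccccc4N)cc3)CC2)cc1` gives 25.3% in this assay. Of the steps among them, only a number 10.3 percentage points higher from compound 1 to compound 3 (beyond the scatter) lies beyond the scatter; a number 3.4 percentage points higher from compound 1 to compound 2 (within the scatter) and a number 6.9 percentage points higher from compound 2 to compound 3 (within the scatter) do not, so compound 3 cannot be set apart from compound 2 on these numbers, and only its gap to compound 1 counts as real.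

Compound 4 `Nc1ccccc1NC(=O)c1ccc(CSC(=S)N2CCN(Cc3ccccc3)CC2)cc1` has not yet been measured. It differs from compound 3 in one place: benzyl in place of 4-methoxyphenyl on an amine nitrogen in a ring. Two measured steps also change the group on the amine nitrogen in the ring: a number 3.4 percentage points higher from compound 1 to compound 2 (within the scatter) and a number 6.9 percentage points higher from compound 2 to compound 3 (within the scatter), each within the scatter. Replacing the group at that position has so far moved the read-out little, so the step of a number 5.3 percentage points lower from compound 3 to compound 4 (within the scatter) is expected to stay within the scatter as well. Compound 4 is therefore estimated at 20% in this assay, with a range from 9% to 31%.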

Compound 4, a percentage reported as inhibition, at one concentration (the size of the read-out at that concentration, not a potency): 18.1%
Compound 4: middle estimate off by 1.9 percentage points, on the high side, and the stated range covers the measured number.
By their numbers in this assay, from the lowest: compounds 1, 4, 2 and 3 (each within the scatter of the next, the first and the last beyond it).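

With benzyl on the amine nitrogen in the ring, all three new steps stay within the scatter in this assay: one is (a number 7.2 percentage points lower from compound 3 to compound 4 (within the scatter)), another (a number 0.3 percentage points lower from compound 2 to compound 4 (within the scatter)) and the third (a number 3.1 percentage points higher from compound 1 to compound 4 (within the scatter)). The swap of pyridin-4-yl for phenyl on the saturated chain carbon, the first change seen at that spot, gives values that cannot be told apart, and benzyl cannot be separated from either 4-methoxyphenyl or 4-chlorophenyl, although those two lie beyond the scatter of each other. Nothing available explains why these steps are so small.

Every group shown on this nitrogen carries a six-membered aromatic ring, so the effect of a cyclohexyl group, a plain methyl or a longer chain such as 2-phenylethyl stays open. A read-out at one concentration also gives no potency for any of these compounds.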